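Pyrrolidine for morpholine on a chromone dithiocarbamate

The source may report more compounds than this note shows. Statements on the series, on what has been measured and on what is new or still open speak of the compounds shown alone.

Compound 1 `O=c1cc(CSC(=S)N2CCCC2)oc2cc(Cl)ccc12`: > 25000 nM
Compound 2 `COc1ccc2occ(CSC(=S)N3CCOCC3)c(=O)c2c1`: > 40000 nM
Compound 3 `O=c1cc(CSC(=S)N2CCOCC2)oc2cc(Cl)ccc12`: > 25000 nM

Of the compounds shown here, three have been measured in a functional assay on LM7 cells (Homo sapiens) for antiproliferative activity, read by MTT assay, with a stated time of 72 h; on this read-out higher numbers stand for weaker inhibition and lower numbers for stronger inhibition. For compound 3 the value is a limit of the assay, > 25000 nM. For compound 1 the value is likewise a limit, > 25000 nM. For compound 2 the value is a limit as well, > 40000 nM. Compound 1 differs from compound 3 by pyrrolidin-1-yl in place of morpholin-4-yl on a thiocarbonyl carbon; the step that the two limits leave unreadable from compound 3 to compound 1 cannot be read, because both ends sit at the limit of > 25000 nM in this assay, at which 2 of the 3 values shown sit.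

The difference between the core of compound 2 and the core of compound 3 is not broken down here. Compound 4 `COc1ccc2occ(CSC(=S)N3CCCC3)c(=O)c2c1` is not yet measured; it differs from compound 2 by pyrrolidin-1-yl in place of morpholin-4-yl on a thiocarbonyl carbon, the same change as from compound 3 to compound 1, at the same place. In this assay the step is expected to be a step that the limit leaves unreadable from compound 2 to compound 4, resting on compound 2 sitting at the limit of > 40000 nM in this assay, at which 1 of the 3 values shown sits, and on the unreadable step from compound 3 to compound 1. Compound 4 is therefore estimated at 45000 nM, with a likely range from 15000 nM to 120000 nM.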

Compound 4, half-maximal inhibitory concentration: 6000 nM
Estimate against measurement, compound 4: 7.5-fold (0.88 log units) above; measured number outside the range, below it.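

In this assay, pyrrolidin-1-yl in place of morpholin-4-yl on a thiocarbonyl carbon gives an at least 6.6-fold lower number from compound 2 to compound 4 (0.82 log units; beyond the scatter), and the true size of this step stays open, because the value of compound 2 is only a limit: the limit of > 40000 nM in this assay, at which 1 of the 4 values shown sits.

The same change on the core of compound 3 cannot be read, because compound 3 and compound 1 both stand at a limit: the limit of > 25000 nM in this assay, at which 2 of the 4 values shown sit.

The lower number is thus shown on one core only, and the data neither confirm nor rule out that the change carries over to the core of compound 3.

The compounds shown leave open whether pyrrolidin-1-yl is special among amines on the thiocarbonyl carbon of the core of compound 4, or whether piperidin-1-yl or diethylamino would serve as well. They also leave open whether a ring with a second nitrogen, such as 4-methylpiperazin-1-yl, would behave like morpholin-4-yl or like pyrrolidin-1-yl there.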